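Removing the Piperidin-4-yl Group: Expected Effect on Compound 4

This account rests on a few compounds, and the source may have more. Where it says the series, first, only, none or still open, it means among the compounds named here.

Compound 1 `CC(Oc1ncnc2ccc(-c3cnn(C4CCNCC4)c3)cc12)c1c(Cl)ccc(F)c1Cl` gives 6770 nM in a functional assay on MDA-MB-231 cells (Homo sapiens) for antiproliferative activity, read by MTT assay, with a stated time of 72 h; on this read-out lower numbers stand for stronger inhibition and higher numbers for weaker inhibition. Compound 2 `CC(Nc1ncnc2ncc(-c3cnn(C4CCNCC4)c3)cc12)c1c(Cl)ccc(F)c1Cl` gives 7110 nM in this assay. Compound 3 `CC(Nc1ncnc2ncc(-c3cnn(C)c3)cc12)c1c(Cl)ccc(F)c1Cl` reaches only a limit of this assay, > 100000 nM.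

Compound 1 and compound 2 carry the same side chain, but the difference between their two cores is not broken down here; their two numbers lie within the scatter of each other. From compound 2 to compound 3 the change is methyl in place of piperidin-4-yl on an aromatic nitrogen, and it brought an at least 14-fold higher number from compound 2 to compound 3 (1.14 log units; beyond the scatter), the number for compound 3 sitting at the limit of > 100000 nM in this assay, at which 1 of the 3 values shown sits. Compound 4 `CC(Oc1ncnc2ccc(-c3cnn(C)c3)cc12)c1c(Cl)ccc(F)c1Cl` has not yet been measured; relative to compound 1 it carries the same change, (methyl in place of piperidin-4-yl on an aromatic nitrogen), at the same place. Resting on an at least 14-fold higher number from compound 2 to compound 3 (1.14 log units; beyond the scatter), a step of similar size is expected here, a 13-fold higher number from compound 1 to compound 4 (1.12 log units; beyond the scatter). Compound 4 is therefore estimated at 90000 nM, between 30000 nM and 300000 nM, with a real chance that only a limit is reported.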

Compound 4, half-maximal inhibitory concentration: 30000 nM
Beside the measured number, compound 4's estimate is 3.0-fold (0.48 log units) above it; the measured number falls inside the stated range.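

In this assay, methyl in place of piperidin-4-yl again gave weaker inhibition on the core of compound 1, showing a 4.4-fold higher number from compound 1 to compound 4 (0.65 log units; beyond the scatter) on this core, so the direction held on both cores shown, though two cores make no rule for the series. The size of the step did not carry over unchanged: the same change on two cores in this assay, an at least 14-fold higher number (1.14 log units; beyond the scatter) from compound 2 to compound 3 and a 4.4-fold higher number (0.65 log units; beyond the scatter) from compound 1 to compound 4, at least 3.1-fold (0.50 log units) apart, beyond the scatter of two such steps. As far as these compounds go, compound 3 is reported only as a limit, so the step on its core and the gap between the two steps are lower bounds, and their true sizes remain unknown: the limit of > 100000 nM in this assay, at which 1 of the 4 values shown sits.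

The compounds shown leave open what an open-chain amine or a carboxylic acid would give on that aromatic nitrogen. They also leave open whether the ring or its nitrogen matters more, which a cyclohexyl group there could test.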